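A few compounds are considered here, and "the series" means these few. Any claim that something is new, unique, unknown or untested is made for them only; others in the source may bear on it.

Compound 2 `Oc1cccc(-c2cc(-c3ccncc3)nc(-c3cccc(Cl)c3)c2)c1` carries a pyridin-4-yl group on the shared core, alongside a 3-chlorophenyl group and a 3-hydroxyphenyl group on that same core. In an ADME assay on HEK293 cells (Homo sapiens) for cytotoxicity, read by CCK-8 assay and cell counting, with a stated time of 2 days (on this read-out lower numbers stand for stronger inhibition and higher numbers for weaker inhibition), compound 2 stands as "not determined" (no result reported): no result was reported for it. Two relatives of compound 2 do have numbers. Compound 1 `Oc1ccc(-c2cc(-c3ccccc3)nc(-c3ccccc3Cl)c2)cc1` gives 3930 nM in this assay. Compound 3 `Oc1cccc(-c2cc(-c3ccc(Cl)cc3)nc(-c3cccnc3)c2)c1` gives 39500 nM in this assay. Each of these two differs from compound 2 in more than one place, so their numbers set only a rough frame, and they sit well apart from each other.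

Compound 4 `Oc1cccc(-c2cc(-c3ccsc3)nc(-c3cccc(Cl)c3)c2)c1` is the compound of interest. Its difference from compound 2 is thiophen-3-yl in place of pyridin-4-yl on an aromatic carbon. Going by the values given here, no measured pair in this set shows what such an exchange does in this assay, so no direction and no size of step can be read off for it. Among the compounds with values here, with no number for compound 2 and no comparable pair, the expectation rests on the frame set by compound 1 and compound 3 alone. A result for compound 4 somewhere inside that frame is expected, with a wide range to match the missing anchor. Compound 4 is estimated at 15000 nM in this assay, with a range from 4000 nM to 60000 nM.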

Compound 4, half-maximal inhibitory concentration: 3180 nM
Estimate against measurement, compound 4: 4.7-fold (0.67 log units) above; the whole stated range lies above it.
By their numbers in this assay, from the lowest: compounds 4 and 1 (each within the scatter of the next); then compound 3.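

In this assay, going by these compounds alone, compound 2 has no number, so the exchange of pyridin-4-yl for thiophen-3-yl that leads to compound 4 gives no step that can be read. No measurement shown here offers an explanation for the result of compound 4. The compounds shown leave open how a single change at this place on the shared core moves the value.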